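Fluorine placement on the arylsulfonyl group and hepatic extraction

A few compounds are considered here, and "the series" means these few. Any claim that something is new, unique, unknown or untested is made for them only; others in the source may bear on it.

Three compounds of the series have been run in an ADME assay on microsomes from liver (Mus musculus), read by LC-MS, using NADPH, tested at 10 uM; on this read-out higher numbers stand for higher hepatic extraction and lower numbers for lower hepatic extraction. Compound 1 `O=C(NCc1ccccc1)c1ccc(N2CCC(S(=O)(=O)c3cccc(Cl)c3Cl)CC2)nn1` gives 0.75, and compound 3 `O=C(NCc1ccccc1)c1ccc(N2CCN(S(=O)(=O)c3ccccc3Cl)CC2)nn1` gives 0.97. Compound 2 `Cc1ccc(F)cc1S(=O)(=O)N1CCN(c2ccc(C(=O)NCc3ccc(F)cc3)nn2)CC1` gives 0.47, the lowest of the three; compound 1 lies higher, beyond the scatter, and compound 3 higher still, also beyond the scatter. Compound 4 `Cc1cc(F)ccc1S(=O)(=O)N1CCN(c2ccc(C(=O)NCc3ccc(F)cc3)nn2)CC1` is not yet measured. It differs from compound 2 in one place: 4-fluoro-2-methylphenyl in place of 5-fluoro-2-methylphenyl on a sulfonyl sulfur. Going by the values given here, no measured pair shows this change, so its effect in this assay is unknown. For compound 4 the expected step is a number 0.030 higher from compound 2 to compound 4 (within the scatter), no more than the scatter in either direction. Compound 4 is therefore estimated at 0.5, within 0.35 to 0.65.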

Compound 4, hepatic extraction ratio: 0.8
The estimate for compound 4 lay 0.30 below the measured number, outside the stated range (above it).
By their numbers in this assay, from the lowest: compound 2; then compounds 1 and 4 (each within the scatter of the next); then compound 3.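

The change from 5-fluoro-2-methylphenyl to 4-fluoro-2-methylphenyl on a sulfonyl sulfur gives, in this assay, a number 0.33 higher from compound 2 to compound 4 (beyond the scatter). This group is therefore sensitive to where its fluorine sits, even with the same atoms and the same counts on both sides, which compounds 1 and 3 could not show. Nothing at hand bears on why this change has such a large step.

Open, as far as these compounds go, is how a methoxy group or a nitrile in place of that fluorine would read. Also open, from the compounds shown here alone, is whether the step holds on another member of the series.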